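The source may hold more compounds than are shown below. What is called first, only, known or untested is meant among the compounds shown, and "the series" means these compounds.

Measured so far in a functional assay on the whole organism with Mus musculus as the target, with a stated time of 90 min, at a dose of 30 umol/kg by the oral route; on this read-out lower numbers stand for a weaker effect and higher numbers for a stronger effect at the one dose given: compound 1 `Clc1nc(NC2CC2)c2ncn(C3CCCCO3)c2n1` gives 17%; compound 2 `C[C@H](NC(=O)CN(c1nc(Cl)nc2c1ncn2C1CCCCO1)C1CC1)C(=O)OCc1ccccc1` gives 37.2%; compound 3 `N=C(N)NCCC[C@H](NC(=O)CN(c1nc(Cl)nc2c1ncn2C1CCCCO1)C1CC1)C(=O)OCc1ccccc1` gives 66.7%.

Compound 3 stands highest of the three, above compound 2 and further above compound 1, both gaps beyond the scatter. Compound 4 `O=C(CN(c1nc(Cl)nc2c1ncn2C1CCCCO1)C1CC1)NCC(=O)OCc1ccccc1` differs from compound 3 by a hydrogen atom in place of a group of 7 heavy atoms (4 carbon, 3 nitrogen; no ring), on a saturated chain carbon bound to an amide-type nitrogen and a carbonyl carbon. Going by the values given here, the one step that bears on this is a number 29.5 percentage points higher from compound 2 to compound 3 (beyond the scatter), where a side group entered at a nearby chain carbon and the read-out rose. Compound 4 strips the chain back past that point, so a fall is expected, roughly undoing that gain and perhaps more: a number 33.7 percentage points lower from compound 3 to compound 4 (beyond the scatter). Compound 4 is therefore estimated at 33%, within 18% to 50%.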

Compound 4, a percentage reported as activity, at one dose (the size of the read-out at that dose, not a potency): 31%
Compound 4: middle estimate off by 2 percentage points, on the high side, and the stated range covers the measured number.
By their numbers in this assay, from the lowest: compound 1; then compounds 4 and 2 (each within the scatter of the next); then compound 3.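

In this assay, the saturated chain carbon bound to an amide-type nitrogen and a carbonyl carbon tolerates the loss of methyl without a readable change (a number 6.2 percentage points lower from compound 2 to compound 4 (within the scatter)). Loss of the group of 7 heavy atoms at the same place has a large effect (a number 35.7 percentage points lower from compound 3 to compound 4 (beyond the scatter)), so the read-out here depends on that group and not on just any substituent. No measured evidence accounts for this difference.

Going by these compounds, whether an amine or a carboxylic acid at the end of a chain on this carbon would match compound 3 remains open. So does the effect of a shorter or longer chain.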